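This account rests on a few compounds, and the source may have more. Where it says the series, first, only, none or still open, it means among the compounds named here.

The measured compounds and their values:

Compound 1, `O=C(O[C@H]1C[C@H](n2cc(F)c(=O)[nH]c2=O)O[C@@H]1COP(=O)(O)Oc1ccccc1)c1ccccc1`, gives 6880 nM in a functional assay on T47D cells (Homo sapiens) for cytotoxicity, read by MTT assay, with a stated time of 48 h; on this read-out lower numbers stand for stronger inhibition and higher numbers for weaker inhibition.
Compound 2, `O=C(O[C@H]1C[C@H](n2cc(F)c(=O)[nH]c2=O)O[C@@H]1COP(=O)(O)Oc1ccc2ncccc2c1)c1ccccc1`, gives 7140 nM.
Compound 3, `O=c1[nH]c(=O)n([C@H]2C[C@H](O)[C@@H](COP(=O)(O)Oc3ccccc3)O2)cc1F`, gives 13400 nM.

Compound 3 thus sits at the upper end of these three numbers, yet it is not separated from the others: the step of a 1.9-fold higher number from compound 1 to compound 3 (0.29 log units; within the scatter) lies within the scatter, and the numbers of compound 2 and compound 3 are likewise close to one another. Compound 4, `O=c1[nH]c(=O)n([C@H]2C[C@H](O)[C@@H](COP(=O)(O)Oc3ccc4ncccc4c3)O2)cc1F`, has not yet been measured. It differs from compound 3 in one place: quinolin-6-yl in place of phenyl on an oxygen. Exactly one measured step bears on this exchange, namely the same replacement carried out on the benzoyl-bearing pair, a 1.0-fold higher number from compound 1 to compound 2 (0.02 log units; within the scatter), which produced no shift beyond the scatter. With that single precedent, and nothing in the data to suggest that compound 3 would respond differently from compound 1, one expects the step of a 1.0-fold lower number from compound 3 to compound 4 (0.01 log units; within the scatter) to amount to no change beyond the scatter in this assay. Compound 4 is accordingly estimated at 13000 nM, with a range from 6500 nM to 28000 nM.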

Compound 4, half-maximal inhibitory concentration: 8110 nM
The estimate for compound 4 lay 1.6-fold (0.20 log units) above the measured number, and the stated range covers the measured number.
By their numbers in this assay, from the lowest: compounds 1, 2, 4 and 3 (each within the scatter of the next).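

In this assay, quinolin-6-yl in place of phenyl on an oxygen whose other neighbours are phosphorus can now be read on a second core, the one without benzoyl, where a 1.7-fold lower number from compound 3 to compound 4 (0.22 log units; within the scatter), and the exchange behaves alike on both cores: the same change on two cores in this assay, a 1.0-fold higher number (0.02 log units; within the scatter) from compound 1 to compound 2 and a 1.7-fold lower number (0.22 log units; within the scatter) from compound 3 to compound 4, 1.7-fold (0.23 log units) apart, within the scatter of two such steps. The new compound also gives a second reading of hydrogen in place of benzoyl on an oxygen on a saturated carbon, now with quinolin-6-yl rather than phenyl on the phosphate side, where a 1.1-fold higher number from compound 2 to compound 4 (0.06 log units; within the scatter), and this exchange also agrees on its two cores: the same change on two cores in this assay, a 1.9-fold higher number (0.29 log units; within the scatter) from compound 1 to compound 3 and a 1.1-fold higher number (0.06 log units; within the scatter) from compound 2 to compound 4, 1.7-fold (0.23 log units) apart, within the scatter of two such steps. Across these four compounds, neither exchange gives a step beyond the scatter, whichever group stands at the other place, so the two exchanges show no dependence on each other in this cytotoxicity read-out.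

The compounds shown span only phenyl and quinolin-6-yl on the phosphate oxygen, and only benzoyl or hydrogen on the other oxygen. As far as these compounds go, whether a simple ethyl chain or a naphthalen-2-yl on the first oxygen, or an acetyl on the second, would move the number beyond the scatter remains open.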